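A Sulfonamide Nitrogen Group Exchanged

The source may report more compounds than this note shows. Statements on the series, on what has been measured and on what is new or still open speak of the compounds shown alone.

In a functional assay on Huh-7 cells (Homo sapiens) for inhibition, read by CCK-8 assay, with a stated time of 72 h (a higher number here means a weaker inhibitor, a lower number a stronger inhibitor), compound 1 `O=C(/C=C/c1cccnc1)NCCCCCCc1cccc(S(=O)(=O)Nc2ccccc2)c1` gives 2.82 nM and compound 2 `Cc1ccc(C)c(NS(=O)(=O)c2cccc(CCCCCCNC(=O)/C=C/c3cccnc3)c2)c1` gives 2.58 nM so the two stand level. Compound 3 `O=C(/C=C/c1cccnc1)NCCCCCCc1cccc(S(=O)(=O)Nc2ccc(C(F)(F)F)cc2)c1` has 4-(trifluoromethyl)phenyl in place of 2,5-dimethylphenyl on a sulfonamide nitrogen. Going by the values given here, the one measured step bearing on this (a 1.1-fold lower number from compound 1 to compound 2 (0.04 log units; within the scatter)) also changed the group on that nitrogen. Among the compounds with values here, no step beyond the scatter is therefore expected in this assay although no measured compound carries trifluoromethyl. The estimate means an expected step (a 1.2-fold higher number from compound 2 to compound 3 (0.07 log units; within the scatter)). For compound 3 the expected value is 3 nM with an estimated range from 1.2 nM to 8 nM as its span.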

Compound 3, half-maximal inhibitory concentration: 164 nM
Beside the measured number, compound 3's estimate is 55-fold (1.74 log units) below it; measured number above the stated range.
By their numbers in this assay, from the lowest: compounds 2 and 1 (each within the scatter of the next); then compound 3.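

In this assay, the group on the sulfonamide nitrogen proves far from indifferent: 4-(trifluoromethyl)phenyl in place of 2,5-dimethylphenyl gives a 64-fold higher number from compound 2 to compound 3 (1.80 log units; beyond the scatter), and trifluoromethyl in place of hydrogen on an aromatic carbon gives a 58-fold higher number from compound 1 to compound 3 (1.76 log units; beyond the scatter). The level standing of compound 1 and compound 2 therefore did not extend to every group there, since this one replacement of hydrogen is enough to separate compound 3 from compound 1. Nothing measured here accounts for the loss. The compounds shown leave open whether 4-methylphenyl or 4-methoxyphenyl on that nitrogen would fall as far, or whether the loss belongs to trifluoromethyl alone.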